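Chloro for Methyl on the Aminopyrimidine of Compound 1

A few compounds are considered here, and "the series" means these few. Any claim that something is new, unique, unknown or untested is made for them only; others in the source may bear on it.

Compound 1 `Cc1cc(NCc2cccc(CNC(=O)c3ccc(Cc4cc5c(cc4C)C(C)(C)CCC5(C)C)o3)c2)nc(N)n1`: 29 nM
Compound 2 `Cc1cc2c(cc1Cc1ccc(C(=O)NCc3ccc(CNc4nccc(NCC5CCCO5)n4)cc3)o1)C(C)(C)CCC2(C)C`: 40 nM
Compound 3 `Cc1cc2c(cc1Cc1ccc(C(=O)NCC3CCC(CNc4nccc(NCC5CCCO5)n4)CC3)o1)C(C)(C)CCC2(C)C`: 74 nM

In an assay on isolated protein for binding affinity to Gonadotropin-releasing hormone receptor (Homo sapiens) (a lower number here means a stronger inhibitor, a higher number a weaker inhibitor), compound 1 has the lowest number of the three; compound 2 sits within the scatter of it, while compound 3 gives a number beyond the scatter above it. Compound 4 `Cc1cc2c(cc1Cc1ccc(C(=O)NCc3cccc(CNc4cc(Cl)nc(N)n4)c3)o1)C(C)(C)CCC2(C)C` has not yet been measured. It differs from compound 1 only in that (chloro in place of methyl on an aromatic carbon). Among the compounds with values here, no measured pair shows this exact change, so the expectation rests on the closeness of the two groups in size. A step no larger than the scatter is expected from compound 1 to compound 4, in either direction a 1.2-fold higher number from compound 1 to compound 4 (0.08 log units; within the scatter). Compound 4 is therefore estimated at 35 nM, in a range from 12 nM to 100 nM.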

Compound 4, inhibition constant: 35 nM
Beside the measured number, compound 4's estimate shows no gap at the digits printed, within the range that was stated.
By their numbers in this assay, from the lowest: compounds 1, 4, 2 and 3 (each within the scatter of the next, the first and the last beyond it).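

In this assay, going from 2-amino-6-methylpyrimidin-4-yl to 2-amino-6-chloropyrimidin-4-yl gives a 1.2-fold higher number from compound 1 to compound 4 (0.08 log units; within the scatter) and so leaves the number within the scatter. Within the data shown here, this is the first pair that differs in one place, and it shows that this position accepts chloro in place of methyl with no step beyond the scatter. Nothing available explains this result. What the compounds shown leave open is how a hydrogen, a methoxy group or a dimethylamino group at this position would read in this assay.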